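Ethyl on a saturated ring carbon of compound 1

The source may hold more compounds than are shown below. What is called first, only, known or untested is meant among the compounds shown, and "the series" means these compounds.

Of the compounds shown here, two have so far been measured in an ADME assay on microsomes from liver (Homo sapiens) for metabolic stability, read by LC-MS, using NADPH, with stated times of 10 min and 30 min; a higher number here means faster removal of the compound, a lower number slower removal. Compound 1 `O=C1c2ccc(Cl)cc2CN1c1cccnc1` gives 12.8 mL/min/kg, the higher of the two numbers. Compound 2 `CC(=O)N[C@@H]1CCCc2c1cncc2N1CCc2cc(Cl)ccc2C1=O` gives 4.3 mL/min/kg, and the gap between the two lies beyond the usual scatter. These two compounds differ in more than one place, so their gap cannot be tied to any single change.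

Compound 3 `CCC1c2cc(Cl)ccc2C(=O)N1c1cccnc1` keeps the core of compound 1 and carries ethyl in place of hydrogen on a saturated ring carbon, next to the ring nitrogen: ethyl in place of hydrogen on a saturated ring carbon. Within the data shown here, no pair of measured compounds isolates this change, so the expectation starts from compound 1 at 12.8 mL/min/kg and has no measured step to lean on. A modest upward step in this assay is expected, one that may well stay within the scatter. The expected size of the move is a 1.3-fold higher number from compound 1 to compound 3 (0.10 log units; within the scatter). For compound 3 the estimated clearance is 16 mL/min/kg, with an expected range of 8 mL/min/kg to 30 mL/min/kg.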

Compound 3, clearance: 6.6 mL/min/kg
Beside the measured number, compound 3's estimate is 2.4-fold (0.38 log units) above it, outside the stated range (below it).
By their numbers in this assay, from the lowest: compounds 2, 3 and 1 (each within the scatter of the next, the first and the last beyond it).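

In this assay, the compounds now offer their first step that changes one place only: ethyl in place of hydrogen on a saturated ring carbon, next to the ring nitrogen, gives a 1.9-fold lower number from compound 1 to compound 3 (0.29 log units; within the scatter). This position, on a five-membered non-aromatic ring and next to the ring atom that bears a pyridin-3-yl group, therefore takes ethyl with a step that cannot be told apart from the usual spread of repeated measurements, something the earlier pair could not show, as it differs in more than one place. No measurement at hand bears on the reason for this result.

This single step leaves open whether methyl, a longer chain such as propyl, or a hydroxyl or an amine on the same ring carbon would also stay within the scatter or would produce a clear step. Compound 2 also leaves open whether ethyl at this position would give a similar step on its more elaborate structure, as the compounds shown include no such single-place pair.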